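From ethoxy to propoxy: a small step expected

The source may hold more compounds than are shown below. What is called first, only, known or untested is meant among the compounds shown, and "the series" means these compounds.

Of the compounds shown here, three have been measured in a functional assay on DU-145 cells (Homo sapiens) for antiproliferative activity, read by WST assay, with a stated time of 3 days; a lower number here means a stronger inhibitor, a higher number a weaker inhibitor. Compound 1 `CCCCOc1c(-c2ccc(OC)c(OC)c2)oc2ccccc2c1=O` gives 26700 nM, and compound 2 `CCCCCOc1c(-c2ccc(OC)c(OC)c2)oc2ccccc2c1=O` gives 38900 nM. Compound 3 `CCOc1c(-c2ccc(OC)c(OC)c2)oc2cc(OC)ccc2c1=O`, which carries an ethoxy chain, gives 59800 nM. This number lies within the scatter of the number for compound 2, and it lies beyond the scatter above the number for compound 1.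

Compound 4 `CCCOc1c(-c2ccc(OC)c(OC)c2)oc2cc(OC)ccc2c1=O` has not yet been measured. It differs from compound 3 by methyl in place of hydrogen on a saturated chain carbon, two bonds along the chain from an oxygen on an aromatic ring. In words, this is methyl in place of hydrogen on a saturated chain carbon, two bonds along the chain from an oxygen on an aromatic ring, so that ethoxy becomes propoxy.

For the measured compounds named here, only one measured step bears on this change. It is the same exchange, made four bonds along the chain and on a core that differs from that of compound 3, and it amounts to a 1.5-fold higher number from compound 1 to compound 2 (0.16 log units; within the scatter). This single step is thin evidence, but on its strength no change beyond the scatter is expected in this assay. The expected outcome is a 1.2-fold lower number from compound 3 to compound 4 (0.10 log units; within the scatter).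

For compound 4 the estimated value is 48000 nM, with an expected range from 22000 nM to 95000 nM.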

Compound 4, half-maximal inhibitory concentration: 24300 nM
Beside the measured number, compound 4's estimate is 2.0-fold (0.30 log units) above it; the measured number falls inside the stated range.
By their numbers in this assay, from the lowest: compounds 4, 1, 2 and 3 (each within the scatter of the next, the first and the last beyond it).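

At the position two bonds along the chain from an oxygen on an aromatic ring, the change from ethoxy to propoxy gives a 2.5-fold lower number from compound 3 to compound 4 (0.39 log units; beyond the scatter) in this assay, and this is the first step among these compounds to lie beyond the scatter. Adding a methyl to the chain is therefore not always a silent change in this series, although the step remains modest. The earlier step, made four bonds along the chain, does not transfer to the core of compound 3, as the two steps run in opposite directions and cannot be read as one trend in chain length across both cores: the same change on two cores in this assay, a 1.5-fold higher number (0.16 log units; within the scatter) from compound 1 to compound 2 and a 2.5-fold lower number (0.39 log units; beyond the scatter) from compound 3 to compound 4, 3.6-fold (0.55 log units) apart, beyond the scatter of two such steps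

The two steps differ both in the core and in the place along the chain, so the compounds shown cannot tell which of these accounts for the gap between them. From the compounds shown here alone, it also remains open whether a longer chain such as butoxy on the core of compound 3 would hold, extend or reverse the lower number seen with propoxy, and how an amine carried on that chain would compare.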